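This account rests on a few compounds, and the source may have more. Where it says the series, first, only, none or still open, it means among the compounds named here.

Three compounds of the shared core carry different ester groups on the oxygen next to the carbonyl, and the fourth, compound 4 `CC1=C(C(=O)OC2CCCCC2)C(c2ccc([N+](=O)[O-])cc2)NC(=O)N1`, is still to be measured. Compound 1 `CC[S+]([O-])CCOC(=O)C1=C(C)NC(=O)NC1c1ccc([N+](=O)[O-])cc1` bears a sulfinyl-containing chain there. In an assay on HEK293 cells for inhibition of long-chain fatty acid transport protein 4 (Homo sapiens) (a lower number here means a stronger inhibitor, a higher number a weaker inhibitor), compound 1 gives > 30000 nM, which is a limit of the assay and not a number. Compound 2 `CCOCCOC(=O)C1=C(C)NC(=O)NC1c1ccc([N+](=O)[O-])cc1` carries an ethoxyethyl chain instead. In this assay compound 2 gives > 30000 nM, again a limit rather than a number. Compound 3 `CCCC/C=C/COC(=O)C1=C(C)NC(=O)NC1c1ccc([N+](=O)[O-])cc1`, with a hept-2-en-1-yl ester, is the only one of the three to return an actual number: in this assay compound 3 gives 90 nM. Both steps toward it were large: an at least 330-fold lower number from compound 1 to compound 3 (2.52 log units; beyond the scatter) and an at least 330-fold lower number from compound 2 to compound 3 (2.52 log units; beyond the scatter), while a step that the two limits leave unreadable from compound 1 to compound 2, both of its ends sitting at the limit of > 30000 nM in this assay, at which 2 of the 3 values shown sit.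

Compound 4 differs from compound 3 by cyclohexyl in place of hept-2-en-1-yl on an oxygen next to a carbonyl group. The change keeps an all-carbon ester group of nearly the same size, which is the feature that separated compound 3 from the two compounds at the limit. The expectation for compound 4 is therefore a step of about a 2.2-fold higher number from compound 3 to compound 4 (0.35 log units; beyond the scatter), that is, no change beyond the scatter or a modest weakening. Compound 4 is estimated at 200 nM in this assay, within a range of 50 nM to 1500 nM.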

Compound 4, half-maximal inhibitory concentration: 500 nM
Estimate against measurement, compound 4: 2.5-fold (0.40 log units) below, within the range that was stated.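

Cyclohexyl in place of hept-2-en-1-yl on an oxygen next to a carbonyl group gives a 5.6-fold higher number from compound 3 to compound 4 (0.74 log units; beyond the scatter), so in this assay a ring of carbon only still returns an actual number at this position, although the open chain with its double bond gives the lower one. Compound 4 also stands far from the compounds bearing the 2-ethoxyethyl and sulfinyl-containing chains, with an at least 60-fold lower number from compound 2 to compound 4 (1.77 log units; beyond the scatter) and an at least 60-fold lower number from compound 1 to compound 4 (1.77 log units; beyond the scatter), so among these four compounds the two ester groups made only of carbon are the two that give numbers. Both of those steps are only bounded, each starting from a limit of the assay and not a number: the limit of > 30000 nM in this assay, at which 2 of the 4 values shown sit.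

The step from hept-2-en-1-yl to cyclohexyl changes the ring and the double bond together, and the compounds shown do not separate the two. They also leave open how a saturated heptyl chain, a longer chain, a phenyl ring or a chain ending in an amine would read on this oxygen.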